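The source may report more compounds than this note shows. Statements on the series, on what has been measured and on what is new or still open speak of the compounds shown alone.

All numbers here come from a physicochemical assay for lipophilicity, at pH 7.4; on this read-out higher numbers stand for higher lipophilicity and lower numbers for lower lipophilicity.
Compound 1 `CCNC(=O)n1ccc(Cn2c(C(=O)CC)c(-c3ccccc3)c3cc(Cl)ccc3c2=O)n1` gives 4.51 in this assay.
Compound 3 `CCC(=O)c1c(-c2ccccc2)c2cc(Cl)ccc2c(=O)n1Cc1cc(C(=O)NC)[nH]n1` gives 3.5 in this assay.
Compound 2 `CCC(=O)c1c(-c2ccccc2)c2cc(Cl)ccc2c(=O)n1Cc1cn(C(=O)NC)c(C)n1` gives "not determined" (no result reported) in this assay, so no number exists for it.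

On the two numbers that exist, compound 3 stands lowest, and its nearest neighbour is compound 1, which lies higher by the step of a number 1.01 log units lower from compound 1 to compound 3 (beyond the scatter) read in reverse. Compound 4 `CCNC(=O)n1cc(Cn2c(C(=O)CC)c(-c3ccccc3)c3cc(Cl)ccc3c2=O)cn1` is not yet measured; it differs from compound 3 by 1-(ethylcarbamoyl)-1H-pyrazol-4-yl in place of 5-(methylcarbamoyl)-1H-pyrazol-3-yl on a saturated chain carbon bound to an aromatic nitrogen. Going by the values given here, only one measured step bears on this change: a number 1.01 log units lower from compound 1 to compound 3 (beyond the scatter), a large step that moved the same attachment from the 1-(ethylcarbamoyl)-1H-pyrazol-3-yl group to the 5-(methylcarbamoyl)-1H-pyrazol-3-yl group. Compound 4 carries the ethylcarbamoyl group back on the pyrazole nitrogen, so a step in the opposite direction, of comparable size, is expected in this assay, with some allowance for the shifted ring attachment. The estimate for compound 4 is 4.4, in the range 3.9 to 4.9, which means an expected step of a number 0.90 log units higher from compound 3 to compound 4 (beyond the scatter).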

Compound 4, distribution coefficient: 4.45
Compound 4: the middle estimate sits 0.05 log units below what was measured; the range from low to high includes it.
By their numbers in this assay, from the lowest: compound 3; then compounds 4 and 1 (each within the scatter of the next).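

Compound 1 and compound 4 both carry the ethylcarbamoyl group on the pyrazole nitrogen, and in this assay exchanging 1-(ethylcarbamoyl)-1H-pyrazol-3-yl for 1-(ethylcarbamoyl)-1H-pyrazol-4-yl gives a number 0.06 log units lower from compound 1 to compound 4 (within the scatter) so this change of ring attachment leaves no measurable mark on the read-out. The new step of a number 0.95 log units higher from compound 3 to compound 4 (beyond the scatter) stands alongside the earlier a number 1.01 log units lower from compound 1 to compound 3 (beyond the scatter) and so, in this set, the gap goes with the 5-(methylcarbamoyl)-1H-pyrazol-3-yl group, whichever of the other two groups it is set against. Nothing measured here gives a cause for that gap.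

The compounds shown do not separate the share of the shorter methylcarbamoyl chain from that of the carbamoyl group's place on the pyrazole. They also leave open how a pyrazole bearing an amine or a carboxylic acid instead of the carbamoyl group would read in this assay on this saturated chain carbon.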